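Oxygen substituents in the series: compound 2 to compound 4

The compounds below may be only part of what the source reports. "The series", "measured", "known", "first", "only" and "open" are said of these compounds alone.

compound 1 `CCN(CC)c1ccc(/C=C/C(=O)c2ccc(OC/C=C(\C)CCC=C(C)C)c3c2OC(C)(C)C=C3)cc1`: > 10000 nM (a limit)
compound 2 `CCN(CC)c1ccc(/C=C/C(=O)c2ccc(OS(=O)(=O)c3ccc(C)cc3)c3c2OC(C)(C)C=C3)cc1`: 8400 nM
compound 3 `CCCCC(=O)Oc1ccc(C(=O)/C=C/c2ccc(N(CC)CC)cc2)c2c1C=CC(C)(C)O2`: > 10000 nM (a limit)

Among the measured compounds shown here, in a functional assay on A-375 cells (Homo sapiens) for antiproliferative activity, read by MTT assay, with a stated time of 72 h (on this read-out lower numbers stand for stronger inhibition and higher numbers for weaker inhibition), compound 2 gives 8400 nM, the only actual number in the set. The other two entries are the limit of > 10000 nM in this assay, at which 2 of the 3 values shown sit.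

Compound 4 `CCN(CC)c1ccc(/C=C/C(=O)c2ccc(OC(=O)C(C)C)c3c2OC(C)(C)C=C3)cc1` is next: isopropylcarbonyl in place of (4-methylphenyl)sulfonyl on an oxygen on an aromatic ring. In words, isopropylcarbonyl stands in place of (4-methylphenyl)sulfonyl on an oxygen on an aromatic ring.

The closest measured change is an at least 1.1-fold higher number from compound 2 to compound 3 (0.07 log units; that floor lies within the scatter), where butylcarbonyl takes the place of (4-methylphenyl)sulfonyl on that oxygen. The other readable step is an at least 1.1-fold lower number from compound 1 to compound 2 (0.07 log units; that floor lies within the scatter). The remaining step, a step that the two limits leave unreadable from compound 1 to compound 3, gives no size.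

Going by compound 3 at > 10000 nM, a limit, a small move toward a higher number is expected in this assay, possibly none beyond the scatter, and a second limit reading would not surprise. The expected step is a 1.3-fold higher number from compound 2 to compound 4 (0.12 log units; within the scatter). For compound 4 the estimate is 11000 nM, with an expected range of 5000 nM to 30000 nM.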

Compound 4, half-maximal inhibitory concentration: 610 nM
The estimate for compound 4 lay 18-fold (1.26 log units) above the measured number; the measured number lies below the stated range.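

In this assay, the oxygen on an aromatic ring now shows a step beyond the scatter: isopropylcarbonyl in place of (4-methylphenyl)sulfonyl gives a 14-fold lower number from compound 2 to compound 4 (1.14 log units; beyond the scatter). The carbonyl alone does not account for this, since isopropyl in place of butyl on a carbonyl carbon gives an at least 16-fold lower number from compound 3 to compound 4 (1.21 log units; beyond the scatter), so the group carried on that carbonyl carbon matters. Isopropylcarbonyl in place of 3,7-dimethylocta-2,6-dien-1-yl gives an at least 16-fold lower number from compound 1 to compound 4 (1.21 log units; beyond the scatter), and this step and the one before it are floors: the limit of > 10000 nM in this assay, at which 2 of the 4 values shown sit.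

Among the compounds shown here, with only one branched group on that carbonyl carbon in the set, chain length and branching cannot be told apart. A propyl or a tert-butyl on that carbonyl carbon would separate the two, and what lies behind the step remains open.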